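A few compounds are considered here, and "the series" means these few. Any claim that something is new, unique, unknown or untested is made for them only; others in the source may bear on it.

Measured so far in a functional assay (aorta) with Oryctolagus cuniculus as the target; a higher number here means a weaker inhibitor, a lower number a stronger inhibitor: compound 1 `OCc1ccc(-c2nn(Cc3ccccc3F)c3ccccc23)o1` at 4900 nM; 4900 nM (2 entries), given as two entries; compound 2 `OCc1ccc(-c2nn(Cc3cccc(F)c3)c3ccccc23)o1` at 10000 nM; compound 3 `N#Cc1ccccc1Cn1nc(-c2ccc(CO)o2)c2ccccc21` at 8700 nM.

Compound 3 holds the lower of the two single numbers, though its gap to compound 2 is described as a 1.1-fold lower number from compound 2 to compound 3 (0.06 log units; within the scatter), which is within the scatter. Compound 4 `OCc1ccc(-c2nn(Cc3cncnc3)c3ccccc23)o1` differs from compound 3 as follows: pyrimidin-5-yl in place of 2-cyanophenyl on a saturated chain carbon bound to an aromatic nitrogen. Among the measured compounds shown here, the only measured step of the same kind, an exchange of the aromatic group on that chain carbon, is a 1.1-fold lower number from compound 2 to compound 3 (0.06 log units; within the scatter), and it did not move this assay beyond the scatter. A similarly small change is therefore expected for compound 4, in this assay estimated at 8000 nM (range 3000 nM to 25000 nM), a step of a 1.1-fold lower number from compound 3 to compound 4 (0.04 log units; within the scatter) that is expected to stay within the scatter.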

Compound 4, half-maximal inhibitory concentration: 3200 nM
Estimate against measurement, compound 4: 2.5-fold (0.40 log units) above; measured number inside the range.
By their numbers in this assay, from the lowest: compound 4; then compounds 3 and 2 (each within the scatter of the next).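

In this assay the aromatic group on a saturated chain carbon bound to an aromatic nitrogen now shows an effect: pyrimidin-5-yl moves the number beyond the scatter against 2-cyanophenyl (a 2.7-fold lower number from compound 3 to compound 4 (0.43 log units; beyond the scatter)) and against 3-fluorophenyl (a 3.1-fold lower number from compound 2 to compound 4 (0.49 log units; beyond the scatter)). The earlier exchange between the two substituted phenyl groups (a 1.1-fold lower number from compound 2 to compound 3 (0.06 log units; within the scatter)) stayed within the scatter, so this position does respond to the aromatic group, though only modestly. Nothing available explains this difference. The compounds shown leave open whether the effect needs both ring nitrogens, as a pyridin-3-yl group would test. They also leave open how a non-aromatic group such as morpholine would fare in this place.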